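The compounds below may be only part of what the source reports. "The series", "measured", "known", "first", "only" and "open" are said of these compounds alone.

In an ADME assay on the whole organism (Rattus norvegicus, strain Wistar Han) for metabolic stability, read by LC-MS, with a stated time of 7 h, at a dose of 1 mg/kg by the intravenous route (a higher number here means that the compound lasts longer, a lower number that the compound disappears faster), compound 1 (`CNC(=O)c1cc(C(=O)NC2CC2)cn([C@H](C)c2ccccc2)c1=O`) gives 0.4 h and compound 2 (`CNC(=O)c1cc(C(=O)NC2CC2)cn(Cc2cccc3[nH]ccc23)c1=O`) gives 0.8 h. These two values lie within the scatter of each other, so compound 2 cannot be separated from compound 1 on the numbers available. Compound 3 (`CNC(=O)c1cc(C(=O)NC2CC2)cn(Cc2cccc([C@@H](C)O)c2)c1=O`) differs from compound 2 in one place, with 3-(1-hydroxyethyl)phenyl in place of 1H-indol-4-yl on a saturated chain carbon bound to an aromatic nitrogen. Among the measured compounds shown here, no measured step covers this change, so no step beyond the scatter is expected in this assay. The expected step is a 1.3-fold lower number from compound 2 to compound 3 (0.12 log units; within the scatter). For compound 3 the estimated value is 0.6 h, with an expected range of 0.3 h to 1.3 h.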

Compound 3, half-life: 0.4 h
For compound 3 the middle estimate is 1.5-fold (0.18 log units) above the measured one; low and high end bracket the measured number.
By their numbers in this assay, from the lowest: compounds 1, 3 and 2 (each within the scatter of the next).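

In this assay, among the compounds shown here, 3-(1-hydroxyethyl)phenyl in place of 1H-indol-4-yl on a saturated chain carbon bound to an aromatic nitrogen gives a first step at this position (a 2.0-fold lower number from compound 2 to compound 3 (0.30 log units; within the scatter)), so the half-life does not separate the two groups. An indole-type group with its five-membered aromatic ring is thus not required to stay within this range, at least for compound 3. Nothing at hand bears on the reason for this result.

Still open, on these data alone, is whether a carboxylic acid or an amine on the phenyl ring would give a step beyond the scatter. As far as these compounds go, the opposite stereocentre of the 1-hydroxyethyl group also remains open.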